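The compounds below may be only part of what the source reports. "The series", "measured", "known", "first", "only" and "open" are said of these compounds alone.

Compound 3 `O=C(CCc1ccccc1F)Nc1nc2ccccc2c(=O)s1` is the starting point here. In an assay on CHO cells for displacement of a labelled ligand from adenosine receptor A3 (Homo sapiens), read by scintillation counting, with a stated time of 60 min (on this read-out lower numbers stand for stronger inhibition and higher numbers for weaker inhibition), compound 3 gives only a limit of the assay, >= 1000 nM. Two related compounds share the same core and the same outcome. Compound 1 `O=C(CCCc1ccccc1)Nc1nc2ccccc2c(=O)s1` gives in this assay a limit, > 1000 nM. Compound 2 `O=C(CCCc1ccc(Cl)c(Cl)c1)Nc1nc2ccccc2c(=O)s1` gives in this assay likewise a limit, > 1000 nM. The two measured steps, a step that the two limits leave unreadable from compound 1 to compound 2 and a step that the two limits leave unreadable from compound 1 to compound 3, cannot be read in size, since the limit of > 1000 nM in this assay, at which 2 of the 3 values shown sit, and the limit of >= 1000 nM in this assay, at which 1 of the 3 values shown sits, are limits of the assay rather than numbers. So compound 3 stands at the weak end that the assay can report, and none of the measured steps gives a readable size.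

Compound 4 `O=C(CCCc1cccc(Cl)c1)Nc1nc2ccccc2c(=O)s1` differs from compound 3 by 3-chlorobenzyl in place of 2-fluorophenyl on a saturated chain carbon, two bonds along the chain from a carbonyl carbon. The measured steps that bear on such a change of the aryl group on the chain are a step that the two limits leave unreadable from compound 1 to compound 2 and a step that the two limits leave unreadable from compound 1 to compound 3, and both are unreadable, so no direction or size can be taken from them. Compound 4 is therefore expected to stay near the limit, and the step that the limit leaves unreadable from compound 3 to compound 4 is expected to lie within the scatter. The estimate for compound 4 in this assay is 3000 nM, with a range from 800 nM to 20000 nM.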

Compound 4, inhibition constant: > 1000 nM
Compound 4: no number, only a limit; the forecaster's own chance of this, stated with the estimate: 80%; the middle value is on the limit's open side.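

Compound 4 also gives only a limit in this assay, so none of the steps linking it to compound 1, compound 2 or compound 3 can be read in size: the limit of > 1000 nM in this assay, at which 3 of the 4 values shown sit.

The compounds shown leave open whether any change to the aryl group on the chain would give a readable number in this assay.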